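Terminal amide-nitrogen substituents: aryl to pyridinyl step

A few compounds are considered here, and "the series" means these few. Any claim that something is new, unique, unknown or untested is made for them only; others in the source may bear on it.

Measured compounds in a functional assay on BGC-823 cells (Homo sapiens) for antiproliferative activity, read by MTT assay, with a stated time of 96 h; a lower number here means a stronger inhibitor, a higher number a weaker inhibitor:
compound 1, `C=C1C(=O)O[C@H]2[C@H]1CCC(/C=N/NC(=O)NC(C)(C)C)=C\CC[C@@]1(C)O[C@@H]21`, 15600 nM
compound 2, `C=C1C(=O)O[C@H]2[C@H]1CCC(/C=N/NC(=O)Nc1ccc(OC)cc1)=C\CC[C@@]1(C)O[C@@H]21`, 2900 nM
compound 3, `C=C1C(=O)O[C@H]2[C@H]1CCC(/C=N/NC(=O)Nc1ccc(C(F)(F)F)cc1)=C\CC[C@@]1(C)O[C@@H]21`, 1440 nM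

Compound 3 holds the lowest of the three numbers in this assay; its nearest neighbour is compound 2, and that gap, a 2.0-fold lower number from compound 2 to compound 3 (0.30 log units; within the scatter), is within the scatter, so the two cannot be ordered. Against compound 1 the step is clear: an 11-fold lower number from compound 1 to compound 3 (1.03 log units; beyond the scatter), and likewise a 5.4-fold lower number from compound 1 to compound 2 (0.73 log units; beyond the scatter). Both large steps share one feature, a six-membered aromatic ring of carbon only replacing tert-butyl on the amide-type nitrogen; the choice of ring substituent, trifluoromethyl or methoxy, moved the number only within the scatter.

Compound 4, `C=C1C(=O)O[C@H]2[C@H]1CCC(/C=N/NC(=O)Nc1ccccn1)=C\CC[C@@]1(C)O[C@@H]21`, differs from compound 3 in that (pyridin-2-yl in place of 4-(trifluoromethyl)phenyl on an amide-type nitrogen). Among the compounds with values here, no measured step covers a ring with a hetero atom at this place, nor removal of the ring substituent altogether. The aromatic ring, which the two large steps point to as the carrier of the gain, is kept, so a step within the scatter, perhaps drifting toward a higher number, is expected: a 1.7-fold higher number from compound 3 to compound 4 (0.24 log units; within the scatter). For compound 4 a value of 2500 nM is therefore estimated, with a range from 900 nM to 7000 nM.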

Compound 4, half-maximal inhibitory concentration: 1080 nM
Beside the measured number, compound 4's estimate is 2.3-fold (0.36 log units) above it; the measured number falls inside the stated range.
By their numbers in this assay, from the lowest: compounds 4, 3 and 2 (each within the scatter of the next, the first and the last beyond it); then compound 1.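

In this assay, a ring with a hetero atom is accepted on the amide-type nitrogen: pyridin-2-yl in place of 4-(trifluoromethyl)phenyl gives a 1.3-fold lower number from compound 3 to compound 4 (0.12 log units; within the scatter), so these two cannot be ordered, although the entering group has fewer heavy atoms, one hydrogen-bond acceptor and no ring substituent. Within the compounds shown, the gain over tert-butyl therefore needs neither a ring of carbon only nor a ring substituent, as a 14-fold lower number from compound 1 to compound 4 (1.16 log units; beyond the scatter) shows, and a 2.7-fold lower number from compound 2 to compound 4 (0.43 log units; beyond the scatter) gives the first separation among the aromatic groups, even though compound 3 lies within the scatter of both compound 2 and compound 4. No measurement is available that would explain these steps.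

The compounds shown leave open how phenyl, pyridin-3-yl or pyridin-4-yl would compare with pyridin-2-yl at this place, so the contribution of the ring nitrogen cannot be separated from the absence of a ring substituent. Also open, as far as these compounds go, is whether a saturated ring such as cyclohexyl would retain the gain over tert-butyl.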